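The compounds below may be only part of what the source reports. "The series", "measured", "known", "first", "only" and "open" are said of these compounds alone.

Measured so far:
- compound 1 `COc1ccc(-c2c[nH]c(=O)n2-c2cc(OC)c(OC)c(OC)c2)cc1OC`: > 50000 nM
- compound 2 `COc1ccc(-c2cn(C(=O)Nc3cc(OC)c(OC)c(OC)c3)c(=O)n2-c2cc(OC)c(OC)c(OC)c2)cc1`: 49700 nM

The read-out is a functional assay on PC-3 cells (Homo sapiens) for cytotoxicity, read by MTT assay, with a stated time of 48 h; on this read-out lower numbers stand for stronger inhibition and higher numbers for weaker inhibition. For compound 1, > 50000 nM is a limit of the assay and not a number. For the measured compounds named here, compound 2, at 49700 nM, gives the only actual number so far.

The next compound is compound 3 `COc1ccc(-c2cn(C(=O)Nc3cc(OC)c(OC)c(OC)c3)c(=O)n2-c2cc(OC)c(OC)c(OC)c2)cc1O`. Its change from compound 2 is hydroxy in place of hydrogen on an aromatic carbon, turning 4-methoxyphenyl into 3-hydroxy-4-methoxyphenyl. Going by the values given here, no measured pair covers this change, so the expectation is loose. A modest move toward stronger inhibition is expected, though a result at the assay limit remains possible. The estimated change is a 2.5-fold lower number from compound 2 to compound 3 (0.40 log units; beyond the scatter). The expected value for compound 3 is 20000 nM, with an estimated range of 3000 nM to 60000 nM.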

Compound 3, half-maximal inhibitory concentration: > 50000 nM
Compound 3: a limit, no number; the forecaster's own chance of this, stated with the estimate: 25%; at least 2.5-fold (0.39 log units) between middle value and limit.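

For the compounds shown here, the hydroxy group, placed on an aromatic carbon ortho to a methoxy group, gives the first one-place comparison, and in this assay it brings no gain in inhibition: a number no lower from compound 2 to compound 3 (the limit leaves the size open). The value of compound 3 is a limit of the assay and not a number, so the step cannot be read for size. It gives a direction only, because compound 3 joins the values at that limit: the limit of > 50000 nM in this assay, at which 2 of the 3 values shown sit.

Going by these compounds, how far compound 3 lies from compound 2 remains open. Also open, on these data alone, is whether an amine or a fluorine on this same aromatic carbon, in place of the hydroxy group, would give a readable number in this assay.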